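A few compounds are considered here, and "the series" means these few. Any claim that something is new, unique, unknown or untested is made for them only; others in the source may bear on it.

Measured so far:
- compound 2, `ClCc1ccccc1Cn1cnc2c(Cl)nc(Cl)nc21`: 3540 nM
- compound 1, `ClCc1ccc(Cn2cnc3c(Cl)ncnc32)cc1`: "not determined" (no result reported)

Among the compounds with values here, compound 2 is the only compound with a number in a functional assay on SNB-75 cells (Homo sapiens) for cytotoxicity, read by sulforhodamine B assay, with a stated time of 48 h; on this read-out lower numbers stand for stronger inhibition of growth and higher numbers for weaker inhibition of growth; compound 1 has the same kind of read-out entry but no value was reported for it, so there is nothing to compare. In this assay compound 2 gives 3540 nM.

Compound 3, `ClCc1ccccc1Cn1cnc2c(Cl)ncnc21`, has not yet been measured. It differs from compound 2 in one place: hydrogen in place of chloro on an aromatic carbon, in words hydrogen in place of chloro on an aromatic carbon. Within the data shown here, no measured pair in this set shows what such a change does, so the direction of the step can only be guessed. Removing a substituent of this kind is expected to cost a little activity at most, roughly a step near the edge of the scatter and not a large loss. Compound 3 is therefore estimated at 5500 nM, with a range from 2000 nM to 15000 nM, which would mean an expected step of a 1.6-fold higher number from compound 2 to compound 3 (0.19 log units; within the scatter).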

Compound 3, concentration for total growth inhibition: 11000 nM
Compound 3: middle estimate off by 2.0-fold (0.30 log units), on the low side; the range from low to high includes it.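

In this assay the chloro group on the aromatic carbon between two ring nitrogen atoms proves to matter: replacing it with hydrogen gives a 3.1-fold higher number from compound 2 to compound 3 (0.49 log units; beyond the scatter) and so weakens growth inhibition by a modest step beyond the usual scatter. Within the data shown here, this is the first direct reading of this position, and it comes from a single pair of compounds that differ in this one place only. Nothing in the data at hand explains why the chloro group gives the stronger result here.

As far as these compounds go, it remains open whether an amine, a methoxy group or a methyl group on this same carbon would match the chloro group or do better. The compounds shown also leave open what would happen if the other chloro group, shared by compound 2 and compound 3, gave way to an amine, or if the chloromethyl group gave way to a longer chain or a carboxylic acid.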